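The source may hold more compounds than are shown below. What is called first, only, known or untested is meant among the compounds shown, and "the series" means these compounds.

In a functional assay on PBMC cells (Homo sapiens) for inhibition, read by HTRF, with stated times of 15 min and 24 h (a higher number here means a weaker inhibitor, a lower number a stronger inhibitor), compound 1 `O=C(Nc1ccc2c(c1)B(O)OC2)c1ccccc1F` gives > 10000 nM, which is a limit and not a number. Compound 2 `COc1ccccc1C(=O)Nc1ccc2c(c1)B(O)OC2` gives > 100000 nM, which is also a limit. Going by the values given here, the only measured step, a step that the two limits leave unreadable from compound 1 to compound 2, puts methoxy in place of fluoro on an aromatic carbon and supplies no readable size. Compound 3 `O=C(Nc1ccc2c(c1)B(O)OC2)c1ccccc1OC(F)(F)F` differs from compound 1 by trifluoromethoxy in place of fluoro on an aromatic carbon, with trifluoromethoxy in place of fluoro on an aromatic carbon. With no size to carry over, only a small expected move toward weaker inhibition is assumed, a step that the limit leaves unreadable from compound 1 to compound 3. Compound 3 is estimated at 20000 nM, within an expected range of 3000 nM to 100000 nM.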

Compound 3, half-maximal inhibitory concentration: > 100000 nM
Compound 3 ended at the assay's limit; the forecaster's own chance of this, stated with the estimate: 70%; middle value at least 5.0-fold (0.69 log units) from the limit.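

Neither the step from compound 1 to compound 3 nor the step from compound 2 to compound 3 can be read, since all three values are limits. The compounds shown leave open how strongly any of them inhibits, and whether fluoro, methoxy and trifluoromethoxy differ at all at this place.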